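The source may report more compounds than this note shows. Statements on the series, on what has been measured and on what is new or still open speak of the compounds shown alone.

Measured so far:
Compound 1 `CC(=O)N(Cc1ncnc2c1ncn2[C@@H]1O[C@H](CO)[C@@H](O)[C@H]1O)C1CCCCC1` gives > 100000 nM in a functional assay on Huh-7 cells (Homo sapiens) for cytotoxicity, read by MTT assay, with a stated time of 3 days (on this read-out lower numbers stand for higher toxicity in this test and higher numbers for lower toxicity in this test), which is a limit of the test rather than a number.
Compound 2 `COCc1ncnc2c1ncn2[C@@H]1O[C@H](CO)[C@@H](O)[C@H]1O` gives > 100000 nM in this assay, again a limit.
Compound 3 `CC(=O)N(Cc1ncnc2c1ncn2[C@H]1C[C@H](O)[C@@H](CO)O1)C1CCCCC1` gives > 100000 nM in this assay, also a limit.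

Compound 2 therefore stands at the limit of the test, so its toxicity on these cells cannot be placed against the other two compounds beyond saying that all three stayed outside the range the test can resolve. Going by the values given here, the only single-point step among the measured compounds, from compound 1 to compound 3, reads a step that the two limits leave unreadable from compound 1 to compound 3, since both of its values are limits.

Compound 4 `O=C1CCCN1Cc1ncnc2c1ncn2[C@@H]1O[C@H](CO)[C@@H](O)[C@H]1O` differs from compound 2 by 2-oxopyrrolidin-1-yl in place of methoxy on a saturated chain carbon bound to an aromatic carbon. Among the compounds with values here, no measured step bears on this change. The whole evidence is the limit of > 100000 nM in this assay, at which 3 of the 3 values shown sit. The expectation is therefore that compound 4 will again sit at the limit of the test, and the step from compound 2 to compound 4 is expected to be a step that the limit leaves unreadable from compound 2 to compound 4, without a readable size. Compound 4 is estimated at 150000 nM, in the range 50000 nM to 500000 nM.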

Compound 4, half-maximal cytotoxic concentration: 45000 nM
For compound 4 the middle estimate is 3.3-fold (0.52 log units) above the measured one; the whole stated range lies above it.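

In this assay, going by these compounds alone, the change to 2-oxopyrrolidin-1-yl gives the first step in this set that can be read: an at least 2.2-fold lower number from compound 2 to compound 4 (0.34 log units; beyond the scatter). This shows that the group on this saturated chain carbon bound to an aromatic carbon can move the read-out into the range the test resolves, with toxicity on these cells now appearing. Within the data shown here, compound 4, at 45000 nM, is the only one with a true number. Compound 1, compound 2 and compound 3 stay at the limit of the test: the limit of > 100000 nM in this assay, at which 3 of the 4 values shown sit.

One change cannot show whether the lower number goes with the ring, with its carbonyl or simply with a larger group. Still open, on these data alone, is what pyrrolidin-1-yl, an amine with the same ring but no carbonyl, or the six-membered 2-oxopiperidin-1-yl would give at this place.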